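A few compounds are considered here, and "the series" means these few. Any claim that something is new, unique, unknown or untested is made for them only; others in the source may bear on it.

Measured so far in an ADME assay on HEK293 cells (Homo sapiens) for cytotoxicity, read by resazurin assay, with a stated time of 72 h (on this read-out lower numbers stand for higher toxicity in this test and higher numbers for lower toxicity in this test), all three being limits:
compound 1 `CCc1cccc(CNC(=O)c2nc3cccc(COc4ccc(C(=O)O)cc4)c3c(=O)[nH]2)c1`: > 20000 nM
compound 2 `CCc1cccc(CNC(=O)c2nc3cccc(COCc4ccc(C(=O)O)cc4)c3c(=O)[nH]2)c1`: > 40000 nM
compound 3 `CCc1cccc(CNC(=O)c2nc3c(F)ccc(COCc4ccc(C(=O)O)cc4)c3c(=O)[nH]2)c1`: > 20000 nM

Compound 3 gives > 20000 nM, which is a limit and not a number. Within the data shown here, the series offers no true number so far, only (the limit of > 20000 nM in this assay, at which 2 of the 3 values shown sit), and (the limit of > 40000 nM in this assay, at which 1 of the 3 values shown sits).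

Compound 4 `CCc1cccc(CNC(=O)c2nc3c(Cl)ccc(COCc4ccc(C(=O)O)cc4)c3c(=O)[nH]2)c1` carries chloro in place of fluoro on an aromatic carbon, para to a ((4-carboxybenzyl)oxy)methyl group: chloro in place of fluoro on an aromatic carbon. The nearest measured change is a step that the two limits leave unreadable from compound 2 to compound 3, with fluoro in place of hydrogen on an aromatic carbon. The other is a step that the two limits leave unreadable from compound 1 to compound 2, with 4-carboxybenzyl in place of 4-carboxyphenyl. Neither has a readable size, and neither shows any sign of toxicity within the range tested in this assay.

No step beyond the usual scatter is therefore expected, and compound 4 will probably again be reported as a limit. The expected size is a step that the limit leaves unreadable from compound 3 to compound 4, which is estimated to stay within the scatter. For compound 4 the estimate is 30000 nM, with an expected range from 15000 nM to 50000 nM.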

Compound 4, half-maximal cytotoxic concentration: > 20000 nM
Compound 4 gave a limit, no number (the forecaster's own chance of this, stated with the estimate: 85%); the middle value lies beyond the limit too.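

In this assay compound 4 gives > 20000 nM, a limit and not a number. The steps to compound 4 from compound 2 and compound 3 cannot be read. The compounds shown leave open whether hydrogen, fluoro or chloro on that aromatic carbon makes any difference in this read-out.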